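This account rests on a few compounds, and the source may have more. Where it says the series, first, only, none or still open, it means among the compounds named here.

Measured so far:
compound 1, `CS/C(=N\C(=O)c1csc([N+](=O)[O-])c1)NC(=O)c1csc([N+](=O)[O-])c1`, > 100000 nM in a functional assay on HepG2 cells (Homo sapiens) for cytotoxicity, read by MTT assay, with a stated time of 72 h; a lower number here means that less compound is tolerated, a higher number that more compound is tolerated
compound 2, `O=C(/N=C(/NC(=O)c1cc(-c2ccccc2)nc2ccccc12)[Se]Cc1ccccc1)c1cc(-c2ccccc2)nc2ccccc12`, 78900 nM in this assay
compound 3, `CS/C(=N\C(=O)c1cc(-c2ccccc2)nc2ccccc12)NC(=O)c1cc(-c2ccccc2)nc2ccccc12`, > 100000 nM in this assay

Compound 1 gives only a limit of the assay, not a number. Compound 3 likewise gives only a limit of the assay. Going by the values given here, compound 2 is the one compound of the three that returns a number. The change from compound 3 to compound 2 is a group of 8 heavy atoms (7 carbon, 1 selenium; one six-membered aromatic ring of carbon only) in place of a group of 2 heavy atoms (1 carbon, 1 sulfur; no ring), on a carbon with a double bond to nitrogen, and it makes an at least 1.2-fold lower number from compound 3 to compound 2 (0.10 log units; that floor lies within the scatter); this step rests on the limit of > 100000 nM in this assay, at which 2 of the 3 values shown sit, and is therefore only a floor on the change.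

The cores of compound 1 and compound 3 differ by a large part of the molecule, and the difference between the two cores is not broken down here.

Compound 4, `O=C(/N=C(/NC(=O)c1csc([N+](=O)[O-])c1)[Se]Cc1ccccc1)c1csc([N+](=O)[O-])c1`, has not yet been measured in this assay. It arises from compound 1 by a group of 8 heavy atoms (7 carbon, 1 selenium; one six-membered aromatic ring of carbon only) in place of a group of 2 heavy atoms (1 carbon, 1 sulfur; no ring), on a carbon with a double bond to nitrogen, which is the same change as that from compound 3 to compound 2, at the same place. Since compound 1 sits at the limit, as compound 3 does, and the measured step from compound 3 to compound 2 is only a floor that lies within the scatter, the expected step is a number no higher from compound 1 to compound 4 (the limit leaves the size open). Compound 4 is estimated at 100000 nM, most likely again a limit, with a range from 40000 nM to 300000 nM.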

Compound 4, concentration lethal to 50% of the cells: 91600 nM
Estimate against measurement, compound 4: 1.1-fold (0.04 log units) above; the range from low to high includes it.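

In this assay, putting the group of 8 heavy atoms, with its selenium and its six-membered aromatic ring, in place of methylsulfanyl on the core of compound 1 gives an at least 1.0-fold lower number from compound 1 to compound 4 (0.03 log units; that floor lies within the scatter). Set beside the earlier step, the change gives a measured number rather than a limit on both cores, and neither core goes against the other, but the two steps can be compared only as floors: the same change on two cores in this assay, an at least 1.2-fold lower number (0.10 log units; that floor lies within the scatter) from compound 3 to compound 2 and an at least 1.0-fold lower number (0.03 log units; that floor lies within the scatter) from compound 1 to compound 4; the limit leaves it open whether they differ. The result therefore shows that the change can be carried to the second core without contradiction, yet it shows neither a real drop on either core nor the true size of either step, since both floors lie within the scatter and both steps start from a limit: the limit of > 100000 nM in this assay, at which 2 of the 4 values shown sit.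

From the compounds shown here alone, what a benzylsulfanyl group or a group of methyl and selenium would give on a carbon with a double bond to nitrogen remains open, so the part played by the selenium stays unseparated from that of the ring. Also open, going by these compounds, is how an amine or a longer chain at that same place would read in this assay, on either core.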